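Cyclohexyl to Isopropyl on the Diene Arm

The source may report more compounds than this note shows. Statements on the series, on what has been measured and on what is new or still open speak of the compounds shown alone.

Of the compounds shown here, two have so far been measured in a functional assay with platelet-activating factor receptor (Cavia porcellus) as the target; on this read-out lower numbers stand for an effect already at smaller amounts and higher numbers for an effect only at larger amounts of compound. Compound 1 `CCCCC/C(=C/C=C/C(=O)N[C@H](C)CCCc1cccnc1)c1ccc(OC)cc1` gives 0.78 mg/kg in this assay. Compound 2 `COc1ccc(/C(=C/C=C/C(=O)N[C@H](C)CCCc2cccnc2)C2CCCCC2)cc1` gives 0.21 mg/kg in this assay and stands with the lowest of the two numbers, its nearest neighbour being compound 1 with a higher number that lies beyond the usual scatter. Compound 3 `COc1ccc(/C(=C/C=C/C(=O)N[C@H](C)CCCc2cccnc2)C(C)C)cc1` has not yet been measured in this assay. It differs from compound 2 in one place: isopropyl in place of cyclohexyl on a double-bonded chain carbon bound to an aromatic carbon and a double-bonded chain carbon. Among the measured compounds shown here, no step between measured compounds covers this change, so the expectation rests only on the two numbers in hand. Compound 3 is expected to move somewhat toward the higher number seen for compound 1, by a step of a 1.9-fold higher number from compound 2 to compound 3 (0.28 log units; within the scatter) in this assay, which may not exceed the usual scatter. The estimate for compound 3 in this assay is 0.4 mg/kg, within a range from 0.15 mg/kg to 1 mg/kg.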

Compound 3, dose for 50% inhibition: 0.41 mg/kg
Compound 3: the middle estimate sits 1.0-fold (0.01 log units) below what was measured; the range from low to high includes it.
By their numbers in this assay, from the lowest: compounds 2, 3 and 1 (each within the scatter of the next, the first and the last beyond it).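

In this assay, among the compounds shown here, putting isopropyl in place of cyclohexyl on a double-bonded chain carbon bound to an aromatic carbon and a double-bonded chain carbon gives a 2.0-fold higher number from compound 2 to compound 3 (0.29 log units; within the scatter) and so provides the first direct reading of this change. At this position, a group of 3 heavy atoms with no ring thus stands in for a six-membered carbon ring of 6 heavy atoms without a difference that exceeds the scatter, so the ring is not shown to be required. No measurement at hand accounts for this result.

The compounds shown leave open whether methyl, cyclopropyl or phenyl would be tolerated in the same place. They also do not show how a chain carrying a hydroxyl group or an amine would read out there.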